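The compounds below may be only part of what the source reports. "The series", "measured", "known", "first", "only" and "open" are said of these compounds alone.

Measured so far in a functional assay on CHO cells for antagonist activity at prostaglandin E2 receptor EP3 subtype (Homo sapiens), read by cAMP accumulation; a higher number here means a weaker inhibitor, a lower number a stronger inhibitor:
compound 1 `CC(C)C(Nc1nnc[nH]1)c1ccc(-c2ccc3cccc(F)c3c2)[nH]c1=O`, 185 nM
compound 2 `CCn1ncc2c(F)cc(-c3ccc(C(CC)(CC)c4nncn4C)c(=O)[nH]3)cc21`, 120 nM
compound 3 `CC(C)C(Nc1nccs1)c1ccc(-c2ccc3cccc(F)c3c2)[nH]c1=O`, 10 nM

Compound 1 gives the highest number of the three; compound 2 sits within the scatter of it, whereas compound 3 lies far lower, by a 19-fold lower number from compound 1 to compound 3 (1.27 log units; beyond the scatter), with 1,3-thiazol-2-yl in place of 4H-1,2,4-triazol-3-yl on an amine nitrogen. Compound 4 `CC(C)C(Cc1nnn[nH]1)c1ccc(-c2ccc3cccc(F)c3c2)[nH]c1=O` differs from compound 1 by (1H-tetrazol-5-yl)methyl in place of (4H-1,2,4-triazol-3-yl)amino on a saturated chain carbon bound to an aromatic carbon and a saturated chain carbon. For the measured compounds named here, no measured step covers this exchange: the step from compound 1 to compound 3 alters only the ring on the amine nitrogen, while in compound 4 the whole (4H-1,2,4-triazol-3-yl)amino group is replaced. That step shows only that this position is sensitive to change. For compound 4 the expected step is a 1.2-fold higher number from compound 1 to compound 4 (0.08 log units; within the scatter) and the estimate is 220 nM, within 40 nM to 1200 nM.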

Compound 4, half-maximal inhibitory concentration: 134 nM
Beside the measured number, compound 4's estimate is 1.6-fold (0.22 log units) above it; the range from low to high includes it.
By their numbers in this assay, from the lowest: compound 3; then compounds 2, 4 and 1 (each within the scatter of the next).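

In this assay the exchange of (4H-1,2,4-triazol-3-yl)amino for (1H-tetrazol-5-yl)methyl gives (a 1.4-fold lower number from compound 1 to compound 4 (0.14 log units; within the scatter)), so on this saturated chain carbon the whole group can change, amine nitrogen included, without a readable shift. The (1,3-thiazol-2-yl)amino group of compound 3 stays apart (a 13-fold higher number from compound 3 to compound 4 (1.13 log units; beyond the scatter)), so the sensitivity at this position does not extend to this exchange. Nothing measured explains either step.

Open, going by these compounds, is whether the low number of compound 3 needs its amine nitrogen, which (1,3-thiazol-2-yl)methyl on the same carbon would settle. Also open, on these data alone, is whether a carboxylic acid there would sit with compound 1 or compound 3.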